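The source may hold more compounds than are shown below. What is called first, only, known or untested is meant among the compounds shown, and "the series" means these compounds.

- Compound 1 (`Cc1cc(C)cc(S(=O)(=O)c2c(C(=O)Nc3ccccc3O)[nH]c3ccc(Cl)cc23)c1`): 19700 nM
- Compound 2 (`Cc1cc(C)cc(S(=O)(=O)c2c(C(=O)NCc3cccc(O)c3)[nH]c3ccccc23)c1`): > 5190 nM
- Compound 3 (`Cc1cc(C)cc(S(=O)(=O)c2c(C(=O)NCc3cccc(O)c3)[nH]c3ccc(Cl)cc23)c1`): 27000 nM

Among the measured compounds shown here, in an ADME assay on MT4 cells (Homo sapiens) for cytotoxicity, read by MTT assay (a lower number here means that less compound is tolerated, a higher number that more compound is tolerated), compound 3 gives 27000 nM as one of only two true numbers. The other comes from compound 1, and the gap between them, a 1.4-fold higher number from compound 1 to compound 3 (0.14 log units; within the scatter), does not separate them. Compound 2 gives > 5190 nM as a limit and not a number. This leaves a step that the limit leaves unreadable from compound 2 to compound 3, so the effect of the chloro group cannot be sized.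

Compound 4 (`COc1cc(CNC(=O)c2[nH]c3ccc(Cl)cc3c2S(=O)(=O)c2cc(C)cc(C)c2)ccc1O`) carries 4-hydroxy-3-methoxyphenyl in place of 3-hydroxyphenyl on a saturated chain carbon bound to an amide-type nitrogen. For the measured compounds named here, the closest guide is the one readable change to the group on the amide nitrogen, a 1.4-fold higher number from compound 1 to compound 3 (0.14 log units; within the scatter), which stayed within the scatter. On that single step, no change beyond the scatter is expected here. The expected result is a 1.1-fold lower number from compound 3 to compound 4 (0.05 log units; within the scatter) (an estimate). For compound 4 the estimated value is 24000 nM, with an expected range of 10000 nM to 55000 nM.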

Compound 4, half-maximal cytotoxic concentration: 28700 nM
Beside the measured number, compound 4's estimate is 1.2-fold (0.08 log units) below it, within the range that was stated.
By their numbers in this assay, from the lowest: compounds 1, 3 and 4 (each within the scatter of the next).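

In this assay, 4-hydroxy-3-methoxyphenyl in place of 3-hydroxyphenyl on a saturated chain carbon bound to an amide-type nitrogen gives a 1.1-fold higher number from compound 3 to compound 4 (0.03 log units; within the scatter). Among the compounds shown here, replacing the 2-hydroxyphenyl group on the amide-type nitrogen with 4-hydroxy-3-methoxybenzyl gives a 1.5-fold higher number from compound 1 to compound 4 (0.16 log units; within the scatter), so this position has now taken a group with an added methoxy without a change beyond the scatter, whereas the earlier compounds gave only one readable swap here. Nothing measured here offers a reason for the lack of a readable change.

As far as these compounds go, all three groups with readable values on this nitrogen carry a hydroxyl on an aromatic ring, so it remains open whether a group ending in an amine or a carboxylic acid would move the number in this assay. Compound 2 gives > 5190 nM, which is a limit and not a number, so the effect of the chloro group stays unreadable.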